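Three Piperazine Propyl Amines Measured, a Fourth Awaited

The compounds below may be only part of what the source reports. "The series", "measured", "known", "first", "only" and "open" are said of these compounds alone.

Within the data shown here, the three compounds measured so far share a propyl chain that joins a ring nitrogen of a six-membered non-aromatic ring with two nitrogens to an aryl-bearing amine nitrogen in that ring. Compound 1 `CCCC(=O)c1c(C)nn(CCCN2CCN(c3ccc(C)cc3)CC2)c(=O)c1N` gives 0% in a functional assay on the whole organism (Abdomen, strain Swiss) for inhibition, with Mus musculus as the target, with stated times of 30 min, 10 min and 5 min, at a dose of 10 mg/kg by the oral route; on this read-out higher numbers stand for a stronger effect at the one dose given and lower numbers for a weaker effect. Compound 2 `C=Cc1c(C)nn(CCCN2CCN(c3ccc(F)cc3)CC2)c(=O)c1N` gives 0% in this assay. Compound 3 `CC(=O)c1cccn1CCCN1CCN(c2cccc(Cl)c2)CC1` gives 3% in this assay, which is the highest of the three numbers, though its nearest neighbour, compound 1, sits within the scatter of it, and so does compound 2. Among the measured compounds shown here, no compound here can be called more or less active than another.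

Compound 4 `CC(=O)c1cccn1CCCN1CCN(c2ccc(C)cc2)CC1` differs from compound 3 in one place: 4-methylphenyl in place of 3-chlorophenyl on an amine nitrogen in a ring. For the measured compounds named here, no step between two measured compounds isolates this change. What the data do show is that compound 1, which also carries a 4-methylphenyl on the amine nitrogen in a ring, gives 0%, and that all three numbers lie within the scatter of one another. Compound 4 is therefore expected to stay near the floor, with a step from compound 3 of about a number 1 percentage points lower from compound 3 to compound 4 (within the scatter), no larger than the scatter in either direction. The estimate for compound 4 in this assay is 2%, expected to fall between 0% and 12%.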

Compound 4, a percentage reported as inhibition, in the whole organism at one dose (the size of the read-out at that dose, not a potency): 12%
The estimate for compound 4 lay 10 percentage points below the measured number; low and high end bracket the measured number.
By their numbers in this assay, from the lowest: compounds 1, 2, 3 and 4 (each within the scatter of the next, the first and the last beyond it).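

Among these compounds, this exchange gives the first reading at this position with the rest of the structure held constant: in this assay, 4-methylphenyl in place of 3-chlorophenyl on an amine nitrogen in a ring gives a number 9 percentage points higher from compound 3 to compound 4 (within the scatter). Since that step lies within the scatter, the exchange cannot be said to alter the read-out at the one dose given, and this single pair offers no ranking of the two aryl groups. Nothing measured on these compounds bears on what lies behind this result.

The exchange also alters two things at once, the substituent and its printed ring position, so 3-methylphenyl and 4-chlorophenyl would be needed on the same core to tell those two contributions apart. Whether a plain phenyl, a 4-methoxyphenyl or a longer chain in place of the propyl chain would move the read-out beyond the scatter on the core of compound 4 remains open, as does how any of these compounds would behave at another dose.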